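This account rests on a few compounds, and the source may have more. Where it says the series, first, only, none or still open, it means among the compounds named here.

Measured compounds:
- compound 1, `Cc1n[nH]c(C(=O)O)c1Cc1ccccc1-c1ccc(F)cc1`: 21%
- compound 2, `Cc1n[nH]c(C(=O)O)c1Cc1ccc(C(F)(F)F)cc1`: 35%
- compound 3, `Cc1n[nH]c(C(=O)O)c1Cc1ccccc1Oc1ccccc1`: 10%

All three share one core and differ only in the group carried on the benzyl ring. They were tested in an assay on isolated protein for inhibition of 2-Hydroxyacid oxidase 2 (Rattus norvegicus), tested at 1 uM; a lower number here means a weaker effect, a higher number a stronger effect of the compound at the concentration tested. Among them compound 2 gives the highest number, with compound 1 coming nearest and compound 3 furthest; both gaps lie beyond the scatter, so compound 2 is the strongest of the three on these numbers.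

The unmeasured compound 4, `Cc1n[nH]c(C(=O)O)c1Cc1ccc(C#N)cc1`, differs from compound 2 in one place: cyano in place of trifluoromethyl on an aromatic carbon.

Among the compounds with values here, only one measured step exists, a number 11 percentage points lower from compound 1 to compound 3 (beyond the scatter), and it concerns a different exchange on a different part of the ring, so it does not bear directly on the swap from trifluoromethyl to cyano. Within the data shown here, it shows only that a change of the pendant group can shift this assay by a modest amount. With no closer comparison, the expected outcome for compound 4 is a small downward step, a number 9 percentage points lower from compound 2 to compound 4 (within the scatter), which may not exceed the scatter. Compound 4 is therefore estimated at 26% in this assay, within a range from 10% to 42%.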

Compound 4, a percentage reported as inhibition, at one concentration (the size of the read-out at that concentration, not a potency): 33%
Beside the measured number, compound 4's estimate is 7 percentage points below it; low and high end bracket the measured number.
By their numbers in this assay, from the lowest: compound 3; then compound 1; then compounds 4 and 2 (each within the scatter of the next).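

In this assay, exchanging trifluoromethyl for cyano on the aromatic carbon para to a large group gives a number 2 percentage points lower from compound 2 to compound 4 (within the scatter) and so does not separate the two groups. This is the only measured exchange shown at this position, and it shows that the read-out stays within the scatter even though cyano has fewer heavy atoms than trifluoromethyl and brings a triple bond and a hydrogen-bond acceptor. No measurement among those available offers an explanation for this result.

From the compounds shown here alone, whether a methoxy group, an amine, a carboxylic acid or a longer chain at this same position would give a similar number remains open. The compounds shown also leave open whether cyano and trifluoromethyl would match each other on a different carbon of the same ring.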